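Anilino swap on a tricyclic core: predicting compound 3

A few compounds are considered here, and "the series" means these few. Any claim that something is new, unique, unknown or untested is made for them only; others in the source may bear on it.

Measured compounds:
compound 1, `COc1ccc(NC2=CC(=O)c3nc4n(c3C2=O)[C@H]2OC[C@@H](O)[C@H]2OC4)cc1`: 1680 nM
compound 2, `O=C1C(NCc2ccccc2)=CC(=O)c2c1nc1n2[C@H]2OC[C@@H](O)[C@H]2OC1`: 3490 nM

Two compounds share a fused core and differ in the group on the amine nitrogen. In a functional assay on MGC-803 cells (Homo sapiens) for inhibition, read by sulforhodamine B assay (on this read-out lower numbers stand for stronger inhibition and higher numbers for weaker inhibition), compound 1 gives 1680 nM and compound 2 gives 3490 nM. Compound 1 therefore has the lowest number of the two, and the gap to compound 2 lies beyond the usual scatter, so compound 1 reads as the stronger inhibitor of the pair.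

Compound 3, `O=C1C=C(Nc2cccc(Cl)c2)C(=O)c2c1nc1n2[C@H]2OC[C@@H](O)[C@H]2OC1`, has not yet been measured. It differs from compound 1 in one place: 3-chlorophenyl in place of 4-methoxyphenyl on an amine nitrogen. Within the data shown here, no measured pair here isolates that kind of change, so the step can only be guessed. The author expects the number for compound 3 to stay close to that of compound 1, with a step of a 1.1-fold lower number from compound 1 to compound 3 (0.05 log units; within the scatter) in this assay, since nothing in the two measured values points to a large move in either direction. The estimate for compound 3 is 1500 nM, with a plausible range from 500 nM to 4500 nM.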

Compound 3, half-maximal inhibitory concentration: 1770 nM
Estimate against measurement, compound 3: 1.2-fold (0.07 log units) below; measured number inside the range.
By their numbers in this assay, from the lowest: compounds 1, 3 and 2 (each within the scatter of the next, the first and the last beyond it).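

In this assay, among these compounds, placing 3-chlorophenyl in place of 4-methoxyphenyl on the amine nitrogen gives a 1.1-fold higher number from compound 1 to compound 3 (0.02 log units; within the scatter), and this is the only step here in which one ring-bearing group on that nitrogen is exchanged for another and the two numbers cannot be told apart. For this one pair, then, the read-out does not separate the two substituted phenyl groups, even though the exchange alters the ring substituent and its place on the ring, and the hydrogen-bond acceptor of the 4-methoxyphenyl group is absent from the 3-chlorophenyl group. Nothing available here explains why the two compounds read alike.

Because substituent and ring place change together in this single step, the compounds shown cannot say what each contributes alone, and 4-chlorophenyl or 3-methoxyphenyl on the same nitrogen would pull the two apart. Also open, going by these compounds, is how far this sameness reaches: whether an unsubstituted phenyl, a 4-trifluoromethylphenyl or a saturated ring such as cyclohexyl on that nitrogen would read like compound 1 and compound 3 remains unknown.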